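From a chlorophenyl to a thiophene on the thiosemicarbazone

The source may report more compounds than this note shows. Statements on the series, on what has been measured and on what is new or still open speak of the compounds shown alone.

Compound 1 `CC1=CC[C@H](C(C)(C)NC(=S)NN)CC1` carries no result in a functional assay on UACC-62 cells (Homo sapiens) for inhibition, read by sulforhodamine B assay, with a stated time of 48 h; a higher number here means a weaker inhibitor of growth, a lower number a stronger inhibitor of growth; the entry for compound 1 is "not determined" (no result reported). Compound 2 `CC1=CC[C@H](C(C)(C)NC(=S)N/N=C/c2ccc(O)cc2)CC1` reaches only the assay limit of > 100000 nM in this assay. Among the compounds with values here, compound 3 `CC1=CC[C@H](C(C)(C)NC(=S)N/N=C/c2cccc(Cl)c2)CC1` gives 9000 nM in this assay, the only full number in this set. Within the data shown here, the single measured step, an at least 11-fold lower number from compound 2 to compound 3 (1.04 log units; beyond the scatter), is large. Compound 4 `CC1=CC[C@H](C(C)(C)NC(=S)N/N=C/c2cccs2)CC1` differs from compound 3 by thiophen-2-yl in place of 3-chlorophenyl on a carbon with a double bond to nitrogen. Among the measured compounds shown here, no measured step alters the ring in this way; the step from compound 2 to compound 3 shows only that exchanging this ring can shift the number strongly, so a moderate change in either direction is plausible. Compound 4 is expected to give 15000 nM, between 4000 nM and 60000 nM. The expected step of a 1.7-fold higher number from compound 3 to compound 4 (0.22 log units; within the scatter) lies within the scatter.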

Compound 4, concentration for 50% growth inhibition: 2600 nM
The estimate for compound 4 lay 5.8-fold (0.76 log units) above the measured number, outside the stated range (below it).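

At this position, on a carbon with a double bond to nitrogen, the lowest number shown does not come from a six-membered ring: in this assay, thiophen-2-yl in place of 3-chlorophenyl gives a 3.5-fold lower number from compound 3 to compound 4 (0.54 log units; beyond the scatter). Thiophen-2-yl in place of 4-hydroxyphenyl gives an at least 38-fold lower number from compound 2 to compound 4 (1.58 log units; beyond the scatter). The entry for compound 2 is a limit of the assay, not a number: the limit of > 100000 nM in this assay, at which 1 of the 4 values shown sits.

The compounds shown leave open whether the sulfur of the thiophene matters, as they include no furan-2-yl ring. They also leave open how an amine on the thiophene ring would shift the number.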